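A few compounds are considered here, and "the series" means these few. Any claim that something is new, unique, unknown or untested is made for them only; others in the source may bear on it.

Measured so far in a functional assay on DU-145 cells (Homo sapiens) for cytotoxicity, read by MTT assay; a lower number here means a stronger inhibitor, a higher number a weaker inhibitor:
- compound 1 `COCCO[C@H](CC=C(C)C)C1=CC(=O)c2c(O)ccc(O)c2C1=O`: 43200 nM
- compound 2 `CC(C)=CC[C@@H](OC(=O)CC(C)(O)C(C)C)C1=CC(=O)c2c(O)ccc(O)c2C1=O`: 16900 nM
- compound 3 `CCC(C)(O)CC(=O)O[C@H](CC=C(C)C)C1=CC(=O)c2c(O)ccc(O)c2C1=O`: 16000 nM

Compound 3, at 16000 nM, cannot be told apart from compound 2, at 16900 nM, while compound 1 has a clearly higher number. Replacing the 2-methoxyethyl group brought modest gains of similar size: a 2.6-fold lower number from compound 1 to compound 2 (0.41 log units; beyond the scatter), and a 2.7-fold lower number from compound 1 to compound 3 (0.43 log units; beyond the scatter). These steps swap a whole group, so they say little about the smaller change ahead.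

The next compound, compound 4 `CCCCC(C)(O)CC(=O)O[C@H](CC=C(C)C)C1=CC(=O)c2c(O)ccc(O)c2C1=O`, keeps that side chain but extends it: ethyl in place of hydrogen on a saturated chain carbon, three bonds along the chain from an oxygen on a saturated carbon. The closest evidence is a single hydrogen-for-methyl swap elsewhere on the same side chain: a 1.1-fold lower number from compound 2 to compound 3 (0.02 log units; within the scatter). Within the data shown here, no measured compound carries a chain this long, so this is thin support. Little change is expected in this assay because a 1.1-fold lower number from compound 2 to compound 3 (0.02 log units; within the scatter) stayed within the scatter, with no clear direction. The expected step is a 1.1-fold lower number from compound 3 to compound 4 (0.06 log units; within the scatter). Compound 4 is estimated at 14000 nM, with an expected range of 6500 nM to 27000 nM.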

Compound 4, half-maximal inhibitory concentration: 76500 nM
Estimate against measurement, compound 4: 5.5-fold (0.74 log units) below; measured number outside the range, above it.
By their numbers in this assay, from the lowest: compounds 3 and 2 (each within the scatter of the next); then compounds 1 and 4 (each within the scatter of the next).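

In this assay this position proves sensitive to chain length, which the earlier hydrogen-for-methyl swap did not reveal: ethyl in place of hydrogen on a saturated chain carbon, three bonds along the chain from an oxygen on a saturated carbon, gives a clear weakening (a 4.8-fold higher number from compound 3 to compound 4 (0.68 log units; beyond the scatter)). Seen another way, butyl in place of isopropyl gives a comparable loss (a 4.5-fold higher number from compound 2 to compound 4 (0.66 log units; beyond the scatter)), while (2-hydroxy-2-methylhexyl)carbonyl in place of 2-methoxyethyl leaves no step that can be told from the scatter (a 1.8-fold higher number from compound 1 to compound 4 (0.25 log units; within the scatter)), so the modest advantage of the shorter side chains does not carry over to this one. Nothing measured here explains the loss.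

Still open, as far as these compounds go, is whether a propyl group at this carbon would already weaken the compound, and whether a longer chain such as hexyl would weaken it further. Also open, from the compounds shown here alone, is how an amine or a carboxylic acid at the end of the chain would behave.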